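The source may hold more compounds than are shown below. What is called first, only, known or untested is meant among the compounds shown, and "the series" means these compounds.

Measured compounds in the series:

- compound 1 `C=CCOc1nc(N)nc2c1ncn2/C=C1/CC1(CO)CO` — > 20000 nM
- compound 2 `CN(C)c1nc(N)nc2c1ncn2/C=C1/CC1(CO)CO` — "not determined" (no result reported)
- compound 3 `CCCNc1nc(N)nc2c1ncn2/C=C1/CC1(CO)CO` — "not determined" (no result reported)

In an ADME assay on MOLT-3 cells (Homo sapiens) for cytotoxicity, with a stated time of 7 days (on this read-out lower numbers stand for higher toxicity in this test and higher numbers for lower toxicity in this test), compound 1 gives > 20000 nM, which is a limit of the assay and not a number. That entry is the limit of > 20000 nM in this assay, at which 1 of the 3 values shown sits. For compound 2 the read-out is "not determined" (no result reported), and for compound 3 it is likewise "not determined" (no result reported), so neither adds a single number. Among the compounds with values here, compound 1 therefore stands alone on this read-out, and only as a limit; no step between measured compounds can be drawn, and nothing is known about how the shared core responds to changes at the position varied here.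

Compound 4 `CSc1nc(N)nc2c1ncn2/C=C1/CC1(CO)CO` is the next to be tested. It differs from compound 1 in one place: methylsulfanyl in place of allyloxy on an aromatic carbon. Since the only reference, compound 1, sits at a limit, the expected size of the step from compound 1 to compound 4 cannot be read from any measured pair; the working expectation is a step of no size beyond the scatter, in no particular direction. The step of a number no higher from compound 1 to compound 4 (the limit leaves the size open) is accordingly expected to be within the scatter. For compound 4 the estimate in this assay is 20000 nM, with a range from 8000 nM to 50000 nM, and it is expected that this assay will again most likely report only a limit rather than a number.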

Compound 4, half-maximal cytotoxic concentration: > 20000 nM
Compound 4: no number, only a limit; the forecaster's own chance of this, stated with the estimate: 75%; the middle value sits exactly at the limit.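

Compound 1 and compound 4 both stand at a limit and not at a number, so no step between them can be read: the limit of > 20000 nM in this assay, at which 2 of the 4 values shown sit.

The compounds shown leave open what half-maximal cytotoxic concentration either compound actually has, and whether methylsulfanyl in place of allyloxy on this aromatic carbon changes it at all.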